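The source may report more compounds than this note shows. Statements on the series, on what has been measured and on what is new or still open speak of the compounds shown alone.

In a functional assay on M21 cells (Homo sapiens) for antiproliferative activity, read by sulforhodamine B assay, with a stated time of 48 h (on this read-out lower numbers stand for stronger inhibition and higher numbers for weaker inhibition), compound 3 `O=C1NCCN1c1ccc(S(=O)(=O)Nc2ccc(Br)cc2)cc1` gives 130 nM, the lowest of the three numbers shown. Compound 2 `Cc1ccccc1NS(=O)(=O)c1ccc(N2CCNC2=O)cc1` gives 150 nM, and the step of a 1.2-fold lower number from compound 2 to compound 3 (0.06 log units; within the scatter) lies within the scatter, so no order between these two is claimed. Compound 1 `COc1ccc(NS(=O)(=O)c2ccc(N3CCNC3=O)cc2)cc1` gives 580 nM; the steps of a 4.5-fold lower number from compound 1 to compound 3 (0.65 log units; beyond the scatter) and a 3.9-fold lower number from compound 1 to compound 2 (0.59 log units; beyond the scatter) are both beyond the scatter. Compound 4 `O=C1NCCN1c1ccc(S(=O)(=O)Nc2ccc(Cl)cc2)cc1` carries the change (chloro in place of bromo on an aromatic carbon). Going by the values given here, no measured step exchanges one halogen for another on this aromatic carbon; the only step at that carbon, a 4.5-fold lower number from compound 1 to compound 3 (0.65 log units; beyond the scatter), replaced methoxy with bromo. With nothing closer to go on, the step of a 1.2-fold higher number from compound 3 to compound 4 (0.06 log units; within the scatter) is expected to stay within the scatter in this assay. Compound 4 is estimated at 150 nM, range 70 nM to 320 nM.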

Compound 4, half-maximal inhibitory concentration: 90 nM
Compound 4: the middle estimate sits 1.7-fold (0.22 log units) above what was measured, and the stated range covers the measured number.
By their numbers in this assay, from the lowest: compounds 4, 3 and 2 (each within the scatter of the next); then compound 1.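

The halogen exchange at this aromatic carbon, para to a large group, now has a direct reading in this assay: a 1.4-fold lower number from compound 3 to compound 4 (0.16 log units; within the scatter) leaves chloro and bromo not told apart. The 2-methylphenyl group on the sulfonamide nitrogen is also not separated from 4-chlorophenyl, with a 1.7-fold lower number from compound 2 to compound 4 (0.22 log units; within the scatter), whereas a 6.4-fold lower number from compound 1 to compound 4 (0.81 log units; beyond the scatter) confirms that the methoxy compound stands apart from the halogen compounds. Still open, as far as these compounds go, is how fluoro, an amine or a carboxylic acid at this carbon would read. No measurement shown here accounts for these differences.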